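Configuration change from compound 1 to compound 4

This account rests on a few compounds, and the source may have more. Where it says the series, first, only, none or still open, it means among the compounds named here.

Among the compounds with values here, in a functional assay on HT-29 cells (Homo sapiens) for cytotoxicity, read by sulforhodamine B assay (a lower number here means a stronger inhibitor of growth, a higher number a weaker inhibitor of growth), compound 1 (`O=C(NCCCCCNC(=O)C1=NO[C@]2(C=C(Br)C(=O)[C@@H](Br)[C@@H]2O)C1)C1=NO[C@]2(C=C(Br)C(=O)[C@@H](Br)[C@@H]2O)C1`) gives 2100 nM, the lowest of the three numbers measured so far. Compound 2 (`COC1=C(Br)[C@H](O)[C@@]2(C=C1Br)CC(C(=O)NCCCCNC(=O)C1=NO[C@]3(C=C(Br)C(=O)[C@@H](Br)[C@@H]3O)C1)=NO2`) gives 5200 nM and compound 3 (`COC1=C(Br)[C@H](O)[C@@]2(C=C1Br)CC(C(=O)NCCCCCNC(=O)C1=NO[C@]3(C=C(Br)C(=O)[C@H](Br)[C@@H]3O)C1)=NO2`) gives 5000 nM. These two values lie within the usual scatter of each other, and both lie beyond the scatter from compound 1.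

Compound 4 (`O=C(NCCCCCNC(=O)C1=NO[C@]2(C=C(Br)C(=O)[C@H](Br)[C@@H]2O)C1)C1=NO[C@]2(C=C(Br)C(=O)[C@H](Br)[C@@H]2O)C1`) has the same atoms and bonds as compound 1 and differs only in configuration as drawn: the two compounds have the same atoms and bonds and differ only in configuration as drawn: 2 of 6 stereo elements differ; a stereocentre at a saturated ring carbon is drawn S in compound 1 and R in compound 4; a stereocentre at a saturated ring carbon is drawn S in compound 1 and R in compound 4. Each change is a stereocentre at a saturated ring carbon, drawn S in compound 1 and R in compound 4.

Within the data shown here, no two measured compounds differ in one place, so the size of this change has no direct measure. Compound 1 already holds the lowest number at 2100 nM, so a rise is thought more likely than a fall. The expected step is a 1.4-fold higher number from compound 1 to compound 4 (0.15 log units; within the scatter), a small rise in this assay that may stay within the scatter. For compound 4 the estimate is 3000 nM, with an expected range from 1200 nM to 7500 nM.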

Compound 4, concentration for total growth inhibition: 2500 nM
Compound 4: middle estimate off by 1.2-fold (0.08 log units), on the high side, and the stated range covers the measured number.
By their numbers in this assay, from the lowest: compounds 1, 4, 3 and 2 (each within the scatter of the next, the first and the last beyond it).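

In this assay, inverting the two stereocentres at saturated ring carbons, drawn S in compound 1 and R in compound 4, gives a 1.2-fold higher number from compound 1 to compound 4 (0.08 log units; within the scatter). Within the data shown here, this is the first step that can be read directly, and it shows that the two configurations, changed together, are not told apart by this assay. The comparison isolates configuration, with no group entering or leaving: the fact that compounds 1 and 4 differ only in the configuration as drawn

The compounds shown leave open what inverting either stereocentre alone would do, as both change together in compound 4. Also open, from the compounds shown here alone, is whether configuration stays without a readable effect in this assay when a longer linking chain or an amine on that chain is present.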